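Working notes: from compound 2 to compound 3

The source may hold more compounds than are shown below. What is called first, only, known or untested is meant among the compounds shown, and "the series" means these compounds.

Measured in an ADME assay on microsomes from liver (Homo sapiens) for metabolic stability, read by LC-MS, using NADPH, with stated times of 5 min and 30 min, tested at 1 uM; on this read-out lower numbers stand for slow clearance and higher numbers for fast clearance:
- compound 1 `O=C1CCCN1c1cnc(NCc2c(F)ccc3c2CCO3)c2cn[nH]c(=O)c12`: 23 mL.min-1.g-1
- compound 2 `Cc1ncccc1-c1cnc(NCc2c(F)ccc3c2CCO3)c2cn[nH]c(=O)c12`: 41 mL.min-1.g-1

Going by the values given here, compound 2 gives 41 mL.min-1.g-1, within the scatter of compound 1, the only other compound measured. The unmeasured compound 3 `CNC(=O)c1cc(-c2cnc(NCc3c(F)ccc4c3CCO4)c3cn[nH]c(=O)c23)n(C)n1` carries 1-methyl-3-(methylcarbamoyl)-1H-pyrazol-5-yl in place of 2-methylpyridin-3-yl on an aromatic carbon.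

Among the compounds with values here, one measured step bears on this change: a 1.8-fold higher number from compound 1 to compound 2 (0.25 log units; within the scatter). It is also a replacement on an aromatic carbon. Within the data shown here, no measured compound carries a five-membered aromatic ring at this place, so this single step offers limited guidance. In this assay, on these data alone, no step beyond the scatter is expected, and the direction remains open. The estimated step is a 1.3-fold lower number from compound 2 to compound 3 (0.12 log units; within the scatter). For compound 3 the estimate is 31 mL.min-1.g-1, with an expected range from 14 mL.min-1.g-1 to 68 mL.min-1.g-1.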

Compound 3, intrinsic clearance in microsomes in the Homo sapiens assay: < 3 mL.min-1.g-1
Compound 3 was reported as a limit; the forecaster's own chance of this, stated with the estimate: 3%; middle value at least 10-fold (1.01 log units) from the limit.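

In the Homo sapiens assay this position can carry a change well beyond the scatter, which the earlier step did not show: 1-methyl-3-(methylcarbamoyl)-1H-pyrazol-5-yl gives an at least 13-fold lower number from compound 2 to compound 3 (1.13 log units; beyond the scatter) and an at least 7.6-fold lower number from compound 1 to compound 3 (0.88 log units; beyond the scatter). In the Homo sapiens assay compound 3 gives < 3 mL.min-1.g-1, which is a limit and not a number. In a physicochemical assay for lipophilicity, using the shake flask method, in phosphate buffer, measured as octanol-water partition, with a stated time of 30 min, at pH 7.4 (on this read-out lower numbers stand for lower lipophilicity and higher numbers for higher lipophilicity), compound 2 gives 3 and compound 3 gives 2.1. Measured in the physicochemical assay, the change to compound 3 also goes with lower lipophilicity, a possible contributor to the slower clearance: the measured distribution coefficient of compound 2, 3, and of compound 3, 2.1, a number 0.90 log units lower (beyond the scatter)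

The five-membered aromatic ring and its methylcarbamoyl enter together, so the compounds shown leave open which of the two carries the step. Also open, on these data alone, is how a carboxylic acid or a nitrile in place of the methylcarbamoyl would read in the Homo sapiens assay.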